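Isoxazole amide in place of cyanophenyl amide

This account rests on a few compounds, and the source may have more. Where it says the series, first, only, none or still open, it means among the compounds named here.

Working notes on the amide series. In an assay on isolated protein for inhibition of Rho-associated protein kinase 1 (Homo sapiens), read by scintillation counting, radiometric assay and 33P incorporation, with a stated time of 40 min, in the presence of a further agent that is not named here (on this read-out lower numbers stand for stronger inhibition and higher numbers for weaker inhibition), compound 3 `N#Cc1ccc(C(=O)Nc2cccc(NC(=O)COc3ccc4c(=O)ccoc4c3)c2)cc1` gives 123 nM, and this sits within the usual scatter of compound 1 `CN(C)c1ccc(C(=O)Nc2cccc(NC(=O)COc3ccc4c(c3)OCCC4=O)c2)cc1`, which in this assay gives 144 nM; no order between the two can be read from these numbers. Compound 2 `Cc1c(OCC(=O)Nc2cccc(NC(=O)c3ccc(N(C)C)cc3)c2)ccc2c(=O)ccoc12` reaches only the limit of this assay, and in this assay compound 2 gives > 10000 nM, a limit rather than a number (the limit of > 10000 nM in this assay, at which 1 of the 3 values shown sits). For the measured compounds named here, two measured numbers and one limit are all that is known, and no step between two measured compounds that differ in one place is available.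

Compound 4 `CC(C)(C)c1cc(C(=O)Nc2cccc(NC(=O)COc3ccc4c(=O)ccoc4c3)c2)no1` has not yet been measured in this assay. It differs from compound 3 in one place: 5-(tert-butyl)-1,2-oxazol-3-yl in place of 4-cyanophenyl on a carbonyl carbon. Going by the values given here, with no measured step of this kind to lean on, the expectation is a modest loss, somewhat beyond the scatter, though a result within the scatter of compound 3 would not surprise. The estimated step from compound 3 to compound 4 in this assay is a 3.3-fold higher number from compound 3 to compound 4 (0.51 log units; beyond the scatter). For compound 4 the estimate in this assay is 400 nM, with a likely range from 100 nM to 2000 nM.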

Compound 4, half-maximal inhibitory concentration: 101 nM
Estimate against measurement, compound 4: 4.0-fold (0.60 log units) above, within the range that was stated.
By their numbers in this assay, from the lowest: compounds 4, 3 and 1 (each within the scatter of the next). At a limit, above all of these: compound 2.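

In this assay, for the compounds shown here, the first step between measured compounds that differ in one place is a 1.2-fold lower number from compound 3 to compound 4 (0.09 log units; within the scatter), and it shows no readable change on exchanging 4-cyanophenyl for 5-(tert-butyl)-1,2-oxazol-3-yl on a carbonyl carbon whose other neighbour is the amide-type nitrogen. For this pair on the shared core, a six-membered aromatic ring of carbon only with a nitrile can thus give way to a five-membered aromatic ring with 2 hetero atoms and a tert-butyl group, with the value staying within the scatter. Going by these compounds alone, the only information available beyond the values concerns the limit reached by compound 2, and it offers no explanation for this step.

As far as these compounds go, whether the position also accepts a carboxylic acid on the aromatic ring, or an open alkyl chain or a piperidine in place of that ring, remains open, as does the separate contribution of the tert-butyl group and the ring that carries it. From the compounds shown here alone, compound 2 gives > 10000 nM, a limit and not a number, and how 5-(tert-butyl)-1,2-oxazol-3-yl would read on the core of compound 2 also remains open.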